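Amide nitrogen substituent swap on the shared core

The source may report more compounds than this note shows. Statements on the series, on what has been measured and on what is new or still open speak of the compounds shown alone.

Compound 1 `O=C(NC1CCCC1)c1cc2ccccc2oc1=O` bears a cyclopentyl group on an amide-type nitrogen of the shared core. For the measured compounds named here, in an assay on CHO cells for displacement of a labelled ligand from adenosine receptor A1 (Homo sapiens), read by scintillation counting, with a stated time of 60 min, tested at 10 uM (on this read-out lower numbers stand for less inhibition and higher numbers for more inhibition at the one concentration tested (going by the name of the read-out)), compound 1 gives 16%, the higher of the two numbers measured so far. Compound 2 `COc1cccc2cc(C(=O)N[C@@H](CO)C(=O)O)c(=O)oc12` gives 12% in this assay; the two values lie within the usual scatter of each other, so neither compound stands apart. Compound 3 `O=C(NCCCO)c1cc2ccccc2oc1=O` awaits measurement and differs from compound 1 by 3-hydroxypropyl in place of cyclopentyl on an amide-type nitrogen. Going by the values given here, no measured step on the shared core exists to guide the estimate, so the expected step of a number 4 percentage points lower from compound 1 to compound 3 (within the scatter) is small, possibly slightly downward, and likely not beyond the scatter. Compound 3 is estimated at 12%, within a range from 0% to 28%.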

Compound 3, a percentage reported as inhibition, at one concentration (the size of the read-out at that concentration, not a potency): 24%
Compound 3: middle estimate off by 12 percentage points, on the low side; measured number inside the range.
By their numbers in this assay, from the lowest: compounds 2, 1 and 3 (each within the scatter of the next, the first and the last beyond it).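

At the amide-type nitrogen of the shared core, the open-chain 3-hydroxypropyl takes the place of the cyclopentyl ring with a step that stays inside the usual scatter in this assay: a number 8 percentage points higher from compound 1 to compound 3 (within the scatter). On this single pair, the ring is therefore not needed to retain the read-out at the one concentration tested. Nothing measured bears on the reason for this step.

Still open, as far as these compounds go, is whether an amine, a carboxylic acid or a longer chain in this place would give a step beyond the scatter. The pair also cannot separate the loss of the ring from the entry of the hydroxyl.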